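The source may hold more compounds than are shown below. What is called first, only, known or untested is meant among the compounds shown, and "the series" means these compounds.

Working notes on the amide aryl group of the series. Compound 1 `Cn1cnc(S(=O)(=O)N2C[C@@H]3[C@H](C2)[C@@]3(CNC(=O)c2ccccc2Cl)CC2CC2)c1` carries a 2-chlorophenyl on the carbonyl carbon and in an assay on isolated protein for inhibition of sodium- and chloride-dependent glycine transporter 1 (Homo sapiens) (on this read-out lower numbers stand for stronger inhibition and higher numbers for weaker inhibition), compound 1 gives 19 nM. Compound 2 `Cn1cnc(S(=O)(=O)N2C[C@@H]3[C@H](C2)[C@@]3(CNC(=O)c2c(Cl)cccc2Cl)CC2CC2)c1` adds a chloro in place of hydrogen on an aromatic carbon; in this assay compound 2 gives 28 nM, and the change is a 1.5-fold higher number from compound 1 to compound 2 (0.17 log units; within the scatter). Compound 3 `Cn1cnc(S(=O)(=O)N2C[C@@H]3[C@H](C2)[C@@]3(CNC(=O)c2cccc(C(F)(F)F)c2)CC2CC2)c1` carries a 3-(trifluoromethyl)phenyl instead and in this assay compound 3 gives 64 nM, the highest of the three numbers, with the steps of a 3.4-fold higher number from compound 1 to compound 3 (0.53 log units; beyond the scatter) and a 2.3-fold higher number from compound 2 to compound 3 (0.36 log units; beyond the scatter).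

Compound 4 `Cn1cnc(S(=O)(=O)N2C[C@@H]3[C@H](C2)[C@@]3(CNC(=O)c2ccc(Cl)cc2)CC2CC2)c1` is the next aryl variant: 4-chlorophenyl in place of 3-(trifluoromethyl)phenyl on a carbonyl carbon. Among the compounds with values here, the steps that bear on this change are the two aryl swaps on the carbonyl carbon already seen, a 3.4-fold higher number from compound 1 to compound 3 (0.53 log units; beyond the scatter) and a 2.3-fold higher number from compound 2 to compound 3 (0.36 log units; beyond the scatter), both modest and both in the direction of a higher number when the trifluoromethyl-bearing ring enters. Returning to a chlorine-bearing ring is therefore expected to give a modest step back toward a lower number in this assay, though the chloro here stands on a different aromatic carbon than in compound 1 or compound 2, so the size is uncertain.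

The expected step is a 1.6-fold lower number from compound 3 to compound 4 (0.20 log units; within the scatter). Compound 4 is estimated at 40 nM, with a range from 15 nM to 110 nM.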

Compound 4, half-maximal inhibitory concentration: 32 nM
Compound 4: the middle estimate sits 1.3-fold (0.10 log units) above what was measured, within the range that was stated.
By their numbers in this assay, from the lowest: compounds 1, 2, 4 and 3 (each within the scatter of the next, the first and the last beyond it).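

Placing the chloro in the 4-chlorophenyl of compound 4 does not separate it from the other two chlorine-bearing aryl groups, with a 1.7-fold higher number from compound 1 to compound 4 (0.23 log units; within the scatter) and a 1.1-fold higher number from compound 2 to compound 4 (0.06 log units; within the scatter) both read in this assay, so these three compounds give no reading on where the chloro stands or whether a second one is present. The change at this position, a 2.0-fold lower number from compound 3 to compound 4 (0.30 log units; within the scatter), also stays within the scatter, which means that compound 3 is set apart from compound 1 and compound 2 but not from compound 4, and chlorine-bearing rings and the trifluoromethyl-bearing ring do not fall into two clean groups. No measurement on hand bears on why these aryl groups on the carbonyl carbon give such similar numbers.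

The step to compound 4 changes the group and its place on the ring together, so a 4-(trifluoromethyl)phenyl or a 3-chlorophenyl would be needed to tell those two apart. As far as these compounds go, how far this position tolerates other kinds of group on the carbonyl carbon, such as a pyridine ring or a phenyl carrying an amine or a carboxylic acid, stays open in this assay for this series.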